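Third methoxy on compound 3: what to expect for compound 4

A few compounds are considered here, and "the series" means these few. Any claim that something is new, unique, unknown or untested is made for them only; others in the source may bear on it.

The series is read in an ADME assay on RAW264.7 cells (Mus musculus) for cytotoxicity, read by MTT assay, with a stated time of 24 h, tested at 2.5 ug/mL; a lower number here means a stronger effect, a higher number a weaker effect of the compound at the concentration tested. Compound 1 `COc1ccc(C(=O)CCc2cccc(OC)c2OC)c(O)c1` gives 95.2% there, compound 2 `COc1ccc(C(=O)CCc2ccc(OC)cc2OC)c(O)c1` gives 96.2%, and compound 3 `COc1ccc(C(=O)CCc2ccc(OC)c(OC)c2)c(O)c1` gives 89%. Compound 3 sits at the low end of the three numbers, but its gap to compound 1 and its gap to compound 2 are both within the scatter, so the three compounds cannot be told apart in this assay; all of them leave the cells largely unaffected at the concentration used.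

Compound 4 `COc1ccc(C(=O)CCc2ccc(OC)c(OC)c2OC)c(O)c1` is not yet measured. It differs from compound 3 by a single change, (methoxy in place of hydrogen on an aromatic carbon), on an aromatic carbon that is ortho to a large group, ortho to a methoxy group and meta to a methoxy group. Within the data shown here, no step between two measured compounds involves this change, and the three measured numbers lie in a narrow band, so nothing here points to a move beyond the scatter in either direction.

Compound 4 is therefore expected to give 92% in this assay, in a range from 80% to 100%, with the step of a number 3 percentage points higher from compound 3 to compound 4 (within the scatter) estimated to stay within the scatter.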

Compound 4, a percentage reported as activity, at one concentration (the size of the read-out at that concentration, not a potency): 94.4%
For compound 4 the middle estimate is 2.4 percentage points below the measured one; the measured number falls inside the stated range.
By their numbers in this assay, from the lowest: compounds 3, 4, 1 and 2 (each within the scatter of the next).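

In this assay, methoxy in place of hydrogen on an aromatic carbon that is ortho to a large group, ortho to a methoxy group and meta to a methoxy group gives a number 5.4 percentage points higher from compound 3 to compound 4 (within the scatter) and so shows that this position accepts the added methoxy with no shift that can be told from the scatter. Read from the other two compounds, the same kind of change gives a number 1.8 percentage points lower from compound 2 to compound 4 (within the scatter) and a number 0.8 percentage points lower from compound 1 to compound 4 (within the scatter) and so puts all of the first steps of this kind in the series within the scatter, whichever compound serves as the starting point. Nothing available bears on why the read-out holds at this position.

Still open, going by these compounds, is whether a group other than methoxy on this aromatic carbon, such as an amine, a carboxylic acid or a longer chain like butoxy, would also stay within the scatter of compound 3. The read-out at one concentration also leaves open whether compound 3 and compound 4 would remain indistinguishable at a higher test concentration.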